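The compounds below may be only part of what the source reports. "The series", "measured", "known", "first", "only" and "open" are said of these compounds alone.

Measured in a functional assay on MGC-803 cells (Homo sapiens) for inhibition, read by MTT assay, with a stated time of 48 h; on this read-out higher numbers stand for weaker inhibition and lower numbers for stronger inhibition:
- Compound 1 `COc1ccc(CN(C(C)=O)c2cc(OC)c(OC)c(OC)c2)cc1O`: 79 nM
- Compound 2 `C/C=C/C(=O)N(Cc1ccc(OC)c(OC)c1)c1cc(OC)c(OC)c(OC)c1`: 20100 nM

Of these two numbers, compound 2 has the higher one, 20100 nM, and so shows the weaker inhibition. Compound 1 sits far lower, and the gap lies well beyond the usual scatter of repeated measurements. The two compounds differ in more than one place, so the gap cannot be pinned on any single change.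

Compound 3 `C/C=C/C(=O)N(Cc1ccc(OC)c(Br)c1)c1cc(OC)c(OC)c(OC)c1` has not yet been measured. It matches compound 2 except at one spot, with bromo in place of methoxy on an aromatic carbon, ortho to a methoxy group and meta to a large group (bromo in place of methoxy on an aromatic carbon). Among the compounds with values here, no measured pair shows this swap alone, so any expectation is loose. Compound 1, at 79 nM, shows that much lower numbers occur among these compounds, which makes a move down from compound 2 seem likelier than a move up. The expected change is a 5.0-fold lower number from compound 2 to compound 3 (0.70 log units; beyond the scatter), towards stronger inhibition. For compound 3 the estimated value is 4000 nM, with an expected range of 300 nM to 30000 nM.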

Compound 3, half-maximal inhibitory concentration: 6430 nM
Compound 3: middle estimate off by 1.6-fold (0.21 log units), on the low side; the range from low to high includes it.
By their numbers in this assay, from the lowest: compound 1; then compound 3; then compound 2.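

In this assay, replacing methoxy with bromo on this aromatic carbon, ortho to a methoxy group and meta to a large group, gives a 3.1-fold lower number from compound 2 to compound 3 (0.49 log units; beyond the scatter) and is the first single change that can be read among these compounds. It shows that this position is not silent: trading a group of 2 heavy atoms and 1 hydrogen-bond acceptor for a lone bromine atom with no acceptor moves the number modestly towards stronger inhibition. Nothing available here accounts for that shift, so the measured step stands without an explanation.

This one pair cannot separate the loss of the methoxy from the arrival of the bromo, and compounds carrying chloro, an amine or a plain hydrogen at this spot would be needed to tell those two apart. It also leaves open whether the same swap would give a step of similar size on a compound with a different amide chain, or at the other methoxy positions on this ring.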